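A few compounds are considered here, and "the series" means these few. Any claim that something is new, unique, unknown or untested is made for them only; others in the source may bear on it.

Compound 3 `CC[C@@H](C)[C@H](NC(=O)c1ccc(C(CC)(CC)c2ccc(OCC(O)C(C)(C)C)c(C)c2)n1CC)C(=O)OC` holds the lowest number of the three compounds measured in an assay on HL-60 cells for agonist activity at vitamin D3 receptor (Homo sapiens), read by microscopy, with a stated time of 96 h; on this read-out lower numbers stand for an effect already at smaller amounts and higher numbers for an effect only at larger amounts of compound: compound 3 gives 26 nM, while compound 1 `CC[C@@H](C)[C@H](NC(=O)c1ccc(C(CC)(CC)c2ccc(OCC(=O)C(C)(C)C)c(C)c2)n1CC)C(=O)OC` gives 590 nM and compound 2 `C#CCCOC(=O)c1ccc(C(CC)(CC)c2ccc(OCC(=O)C(C)(C)C)c(C)c2)n1CC` gives 28800 nM. The step of a 23-fold lower number from compound 1 to compound 3 (1.36 log units; beyond the scatter) is large, as is a 49-fold higher number from compound 1 to compound 2 (1.69 log units; beyond the scatter). Compound 4 `CC[C@@H](C)[C@H](NC(=O)c1ccc(C(CC)(CC)c2ccc(OCC(O)C(C)(C)C)c(C)c2)n1CC)C(=O)O` differs from compound 3 by hydrogen in place of methyl on an oxygen next to a carbonyl group. Within the data shown here, none of the measured steps touches this oxygen, so neither bears directly on it; the only change at the amide end, a 49-fold higher number from compound 1 to compound 2 (1.69 log units; beyond the scatter), replaced a much larger group. Compound 4 is therefore expected to stay near compound 3, with a step of a 1.9-fold higher number from compound 3 to compound 4 (0.28 log units; within the scatter) in this assay, giving an estimate of 50 nM with a range from 8 nM to 300 nM.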

Compound 4, half-maximal effective concentration: 2.3 nM
For compound 4 the middle estimate is 22-fold (1.34 log units) above the measured one; the measured number lies below the stated range.
By their numbers in this assay, from the lowest: compound 4; then compound 3; then compound 1; then compound 2.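

In this assay, an 11-fold lower number from compound 3 to compound 4 (1.05 log units; beyond the scatter) comes from hydrogen in place of methyl on an oxygen next to a carbonyl group, so the loss of a single carbon at this oxygen moves the number beyond the scatter. The earlier steps shown here changed only the whole group on the amide carbonyl or the hydroxy-bearing chain, and did not show that this small ester-to-carboxy change alone counts here. No measurement given here accounts for the fall. The compounds shown leave open how an ethyl ester or a primary amide would compare with the carboxy group. They also leave open whether the same change gives a similar step with (tert-butyl)carbonyl in place of 1-hydroxy-2,2-dimethylpropyl.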